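Swapping a dimethyloxetane for a dioxane: lipophilicity

The source may report more compounds than this note shows. Statements on the series, on what has been measured and on what is new or still open speak of the compounds shown alone.

Compound 1: `CC1(C)C[C@H](CN([C@H](CCC(F)(F)F)C(N)=O)S(=O)(=O)c2ccc(Cl)cc2)O1`, 3.8
Compound 2: `NC(=O)[C@@H](CCC(F)(F)F)N(C[C@@H]1CCCCO1)S(=O)(=O)c1ccc(Cl)cc1`, 4.3
Compound 3: `NC(=O)[C@@H](CCC(F)(F)F)N(C[C@@H]1COCCO1)S(=O)(=O)c1ccc(Cl)cc1`, 2.75

In a physicochemical assay for lipophilicity, read by HPLC, measured as octanol-water partition, at pH 7.4 (on this read-out lower numbers stand for lower lipophilicity and higher numbers for higher lipophilicity), compound 1 stands second highest of the three measured numbers. Its nearest neighbour is compound 2, reached by the step of a number 0.50 log units higher from compound 1 to compound 2 (beyond the scatter). Its furthest is compound 3, reached by the step of a number 1.05 log units lower from compound 1 to compound 3 (beyond the scatter). Between the two other compounds the step is a number 1.55 log units lower from compound 2 to compound 3 (beyond the scatter).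

Compound 4, `NC(=O)[C@@H](CCC(F)(F)F)N(C[C@H]1COCCO1)S(=O)(=O)c1ccc(Cl)cc1`, is not yet measured. It differs from compound 1 in one place: 1,4-dioxan-2-yl in place of 4,4-dimethyloxetan-2-yl on a saturated chain carbon bound to a sulfonamide nitrogen. The entering group is the same 1,4-dioxan-2-yl group that compound 3 carries, so the step from compound 1 to compound 3 is the one that bears most directly on this change, and it was large and downward. A step of similar size and direction is therefore expected here, a number 1.00 log units lower from compound 1 to compound 4 (beyond the scatter).

Compound 4 is estimated to give 2.8, most likely between 2.4 and 3.2.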

Compound 4, distribution coefficient: 2.75
Estimate against measurement, compound 4: 0.05 log units above, within the range that was stated.
By their numbers in this assay, from the lowest: compounds 3 and 4 (each within the scatter of the next); then compound 1; then compound 2.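

In this assay, the new compound gives the first direct test of the drawn configuration at this saturated ring carbon, and the result is no change at the digits printed from compound 3 to compound 4 (within the scatter); this pair reads that one feature alone, because nothing else separates them: the fact that compounds 3 and 4 differ only in the configuration as drawn

The large drop on moving to the 1,4-dioxan-2-yl group therefore does not depend on one drawn form, since the change from the 4,4-dimethyloxetan-2-yl group gives a number 1.05 log units lower from compound 1 to compound 4 (beyond the scatter). The change from the oxan-2-yl group likewise gives a number 1.55 log units lower from compound 2 to compound 4 (beyond the scatter), so both steps repeat in size those seen with compound 3.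

As far as these compounds go, whether configuration is equally silent for the oxan-2-yl and 4,4-dimethyloxetan-2-yl groups stays open, as each appears here in one drawn form only. Also open, from the compounds shown here alone, is how this assay would read if this position carried a ring with an amine nitrogen, such as a morpholine, or a carboxylic acid.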